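Changing the Pendant Ring: From Compound 2 to Compound 3

The source may hold more compounds than are shown below. What is called first, only, known or untested is meant among the compounds shown, and "the series" means these compounds.

Measured compounds:
compound 1, `COc1cccc(OC)c1OCCNCCOc1ccccc1OCc1ccccc1Cl`, 1.41 nM
compound 2, `COc1cccc(OC)c1OCCNCCOc1ccccc1OCc1ccc(Cl)cc1`, 0.251 nM

Within the data shown here, in an assay on CHO cells for displacement of a labelled ligand from Alpha-1A adrenergic receptor (Homo sapiens) (a lower number here means a stronger inhibitor, a higher number a weaker inhibitor), compound 2 gives 0.251 nM, the lowest of the two numbers measured so far; its nearest neighbour is compound 1, which in this assay gives 1.41 nM. Among the measured compounds shown here, the single measured step, a 5.6-fold lower number from compound 1 to compound 2 (0.75 log units; beyond the scatter), is the only one that bears on the new compound. Compound 3, `COc1cccc(OC)c1OCCNCCOc1ccccc1OCc1ccccc1C`, differs from compound 2 as follows: 2-methylphenyl in place of 4-chlorophenyl on a saturated chain carbon bound to an oxygen on an aromatic ring. Since moving the chlorine on that ring changed the number by a 5.6-fold lower number from compound 1 to compound 2 (0.75 log units; beyond the scatter), and compound 3 again carries its substituent at the position the group that leaves in that step occupied, a step back upward beyond the scatter is expected in this assay. For compound 3 the estimate is 1 nM, within 0.3 nM to 3.5 nM. The expected step from compound 2 is a 4.0-fold higher number from compound 2 to compound 3 (0.60 log units; beyond the scatter).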

Compound 3, inhibition constant: 1.59 nM
Compound 3: middle estimate off by 1.6-fold (0.20 log units), on the low side, within the range that was stated.
By their numbers in this assay, from the lowest: compound 2; then compounds 1 and 3 (each within the scatter of the next).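

With the substituent held on the 2-substituted ring, replacing chloro with methyl gives a 1.1-fold higher number from compound 1 to compound 3 (0.05 log units; within the scatter) in this assay, so this assay does not separate these two groups at that position. The other new step, a 6.3-fold higher number from compound 2 to compound 3 (0.80 log units; beyond the scatter), changes both the substituent and its place on the ring, but set beside the first it places 2-methylphenyl with 2-chlorophenyl, while 4-chlorophenyl stays alone at the low end among these three compounds. No measurement available here accounts for these differences.

The compounds shown leave open whether methyl would match chloro in the arrangement of the 4-chlorophenyl group as it does in the 2-substituted one. They also leave open how the number would respond to an amine or a carboxylic acid on this ring in place of chloro or methyl.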